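The source may report more compounds than this note shows. Statements on the series, on what has been measured and on what is new or still open speak of the compounds shown alone.

Series notes, cytotoxicity. Compound 3 `Cc1cc(/C=N/NC(=O)Nc2ccc(Oc3ccnc(-c4nncn4CCN(C)C)c3)c(F)c2)cc(C)c1O` gives 3610 nM in an ADME assay on WI-38 cells (Homo sapiens) for cytotoxicity, read by MTT assay, with a stated time of 72 h (a higher number here means a weaker inhibitor, a lower number a stronger inhibitor), and stands lowest of the two numbers at hand; its nearest neighbour, compound 1 `CN(C)CCn1cnnc1-c1cc(Oc2ccc(NC(=O)N/N=C/c3cccc(Br)c3)cc2F)ccn1`, gives 4230 nM in this assay, within the scatter of compound 3. Compound 2 `CN(C)CCn1cnnc1-c1cc(Oc2ccc(NC(=O)N/N=C/c3ccc(O)c(F)c3)cc2F)ccn1` has no result in this assay: "not determined" (no result reported). Compound 4 `CN(C)CCn1cnnc1-c1cc(Oc2ccc(NC(=O)N/N=C/c3ccc(F)cc3F)cc2F)ccn1` differs from compound 3 as follows: 2,4-difluorophenyl in place of 4-hydroxy-3,5-dimethylphenyl on a carbon with a double bond to nitrogen. Among the measured compounds shown here, the only measured step at the same carbon, a 1.2-fold lower number from compound 1 to compound 3 (0.07 log units; within the scatter), exchanged one aryl for another and stayed within the scatter. No step beyond the scatter is therefore expected here. For compound 4 in this assay the estimate is 4000 nM, with a range from 1500 nM to 10000 nM. This corresponds to an expected step of a 1.1-fold higher number from compound 3 to compound 4 (0.04 log units; within the scatter).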

Compound 4, half-maximal inhibitory concentration: 5030 nM
Beside the measured number, compound 4's estimate is 1.3-fold (0.10 log units) below it; the measured number falls inside the stated range.
By their numbers in this assay, from the lowest: compounds 3, 1 and 4 (each within the scatter of the next).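

In this assay the 2,4-difluorophenyl group gives a 1.4-fold higher number from compound 3 to compound 4 (0.14 log units; within the scatter) and a 1.2-fold higher number from compound 1 to compound 4 (0.08 log units; within the scatter) in the two exchanges on a carbon with a double bond to nitrogen. The position thus tolerates a third aryl, and an aryl with 0 hydrogen-bond donors stays within the scatter of one with 1 hydrogen-bond donor. No evidence bearing on this result is at hand. Open, on these data alone, is whether an aryl carrying an amine or a carboxylic acid, or a cyclohexyl group in place of the aryl, would stay within this narrow band.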